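The source may hold more compounds than are shown below. What is called first, only, known or untested is meant among the compounds shown, and "the series" means these compounds.

Measured so far in a functional assay on Venous blood for antagonist activity at C-X-C chemokine receptor type 3 (Homo sapiens), read by flow cytometry, with a stated time of 30 min, in the presence of a further agent that is not named here; on this read-out lower numbers stand for stronger inhibition and higher numbers for weaker inhibition:
Compound 1, `C[C@@H]1CN(c2sc(C(F)(F)F)nc2-c2nc3ccccc3[nH]2)CCN1C(=O)Cn1ccc(C(=O)O)n1`, gives 5570 nM.
Compound 2, `Cc1nn(CC(=O)N2CCN(c3sc(C(F)(F)F)nc3-c3nc4ccccc4[nH]3)C[C@H]2C)cc1CN(C)C`, gives 330 nM.
Compound 3, `C[C@@H]1CN(c2sc(C(F)(F)F)nc2-c2nc3ccccc3[nH]2)CCN1C(=O)CN1C(=O)OC[C@@H]1c1ccccc1`, gives 1380 nM.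

Among these three, compound 3 stands second highest. Compound 1 lies above it, as shown by the step of a 4.0-fold lower number from compound 1 to compound 3 (0.61 log units; beyond the scatter), and compound 2 lies below it, as shown by the step of a 4.2-fold higher number from compound 2 to compound 3 (0.62 log units; beyond the scatter). All three compounds share one core and differ only in the group on the saturated chain carbon bound to the carbonyl carbon.

Compound 4, `C[C@@H]1CN(c2sc(C(F)(F)F)nc2-c2nc3ccccc3[nH]2)CCN1C(=O)CN1CCC(F)(F)CC1`, changes that same position once more: 4,4-difluoropiperidin-1-yl in place of 2-oxo-4-phenyl-1,3-oxazolidin-3-yl on a saturated chain carbon bound to a carbonyl carbon. The measured steps that bear on this change are the ones at the same position, a 4.0-fold lower number from compound 1 to compound 3 (0.61 log units; beyond the scatter) and a 4.2-fold higher number from compound 2 to compound 3 (0.62 log units; beyond the scatter), together with the largest swing, a 17-fold lower number from compound 1 to compound 2 (1.23 log units; beyond the scatter). They show that this position tolerates quite different groups and that each replacement has moved the number by a modest to large amount, in both directions. Among the compounds with values here, no measured compound carries a group resembling the one that enters, so the direction for compound 4 is uncertain; a modest step in this assay is expected.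

Compound 4 is therefore estimated at 800 nM, with a range from 250 nM to 2500 nM, which would mean an expected step of a 1.7-fold lower number from compound 3 to compound 4 (0.24 log units; within the scatter).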

Compound 4, half-maximal inhibitory concentration: 2430 nM
Compound 4: middle estimate off by 3.0-fold (0.48 log units), on the low side; the measured number falls inside the stated range.
By their numbers in this assay, from the lowest: compound 2; then compounds 3 and 4 (each within the scatter of the next); then compound 1.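

In this assay, within the data shown here, the 4,4-difluoropiperidin-1-yl group is the first group seen on this saturated chain carbon bound to a carbonyl carbon that has no aromatic ring, and the new step (a 1.8-fold higher number from compound 3 to compound 4 (0.25 log units; within the scatter)) stays within the scatter. Compounds 3 and 4 therefore cannot be ranked, even though the group that enters has fewer heavy atoms and no phenyl ring. The other two steps (a 7.4-fold higher number from compound 2 to compound 4 (0.87 log units; beyond the scatter) and a 2.3-fold lower number from compound 1 to compound 4 (0.36 log units; beyond the scatter)) both lie beyond the scatter, so compound 2 keeps the lowest number of the four and compound 1 the highest. No measurement offered here explains any of these steps.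

A plain piperidin-1-yl group at this place would show what the two fluorine atoms contribute, since compound 4 is the only one shown that carries them. On these data alone, it also remains open whether the lower number of compound 2 belongs to its dimethylamino group or to the pyrazole that carries it, and a 4-(dimethylamino)piperidin-1-yl group would test the amine on a ring that is not aromatic.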